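Lengthening the Side Chain of a Quinuclidine Carbamate

The source may hold more compounds than are shown below. What is called first, only, known or untested is meant among the compounds shown, and "the series" means these compounds.

The series centres on compound 1 `O=C(OCCc1ccc(Cl)c(Cl)c1)N(c1ccccc1)C1CN2CCC1CC2`, a carbamate built on a shared core, which in an assay on CHO cells for displacement of a labelled ligand from muscarinic acetylcholine receptor M5 (Homo sapiens), read by scintillation counting, with a stated time of 2 h (on this read-out higher numbers stand for weaker inhibition and lower numbers for stronger inhibition), gives 80 nM. Among the three measured compounds, compound 1 gives the lowest number. Compound 2 `O=C(OCc1ccccc1)N(c1ccccc1)C1CN2CCC1CC2` gives 150 nM in this assay, and compound 3 `COc1ccc(COC(=O)N(c2ccccc2)C2CN3CCC2CC3)cc1OC` gives 550 nM. The step of a 1.9-fold higher number from compound 1 to compound 2 (0.27 log units; within the scatter) is within the scatter, so compound 1 and compound 2 cannot be told apart on these numbers, whereas the gap from compound 1 to compound 3 lies beyond it.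

The next compound, compound 4 `Cc1ccc(CCCOC(=O)N(c2ccccc2)C2CN3CCC2CC3)cc1F`, departs from compound 1 by the change (3-fluoro-4-methylbenzyl in place of 3,4-dichlorophenyl on a saturated chain carbon, two bonds along the chain from an oxygen next to a carbonyl group). Within the data shown here, no measured step covers exactly this exchange. The closest comparison is the step from compound 1 to compound 2, in which the same chain carbon lost its 3,4-dichlorobenzyl substituent for a phenyl with little effect on the number. Compound 3 shows that a substituted benzyl on the shorter chain can push the number higher, so some loss cannot be ruled out. On balance a modest weakening is expected, with the step of a 1.9-fold higher number from compound 1 to compound 4 (0.27 log units; within the scatter) likely to stay within or just beyond the scatter. Compound 4 is therefore estimated at 150 nM, with a range from 50 nM to 450 nM.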

Compound 4, inhibition constant: 130 nM
Compound 4: middle estimate off by 1.2-fold (0.06 log units), on the high side; the measured number falls inside the stated range.
By their numbers in this assay, from the lowest: compounds 1, 4 and 2 (each within the scatter of the next); then compound 3.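

In this assay, exchanging 3,4-dichlorophenyl for 3-fluoro-4-methylbenzyl on a saturated chain carbon, two bonds along the chain from an oxygen next to a carbonyl group, gives a 1.6-fold higher number from compound 1 to compound 4 (0.21 log units; within the scatter) and so leaves the two compounds indistinguishable on these numbers. This is the first step shown at this carbon, and it shows that the place accepts a group of 9 heavy atoms, with 8 carbon and 1 fluorine, in place of one of 8 heavy atoms, with 6 carbon and 2 chlorine, without a change that can be read beyond the scatter. No measurement in hand accounts for this outcome.

The compounds shown leave open whether the ring substituents or the added carbon of the benzyl group contribute separately, since the two differ together in this single exchange, and a 3,4-dichlorobenzyl group at the same carbon would bear on that. They also leave open what an amine or a carboxylic acid at this carbon, or a longer chain, would do to the number.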